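A Nitro Group in Place of Fluorine on Compound 1

The source may report more compounds than this note shows. Statements on the series, on what has been measured and on what is new or still open speak of the compounds shown alone.

For the measured compounds named here, compound 1 `CCOC(=O)C1=Cc2ccccc2OC1(OCc1cn(-c2ccc(F)cc2)nn1)C(F)(F)F` is the only member of this small set with a real number in a functional assay on DU-145 cells (Homo sapiens) for inhibition, read by MTT assay, with a stated time of 24 h; a higher number here means a weaker inhibitor, a lower number a stronger inhibitor: compound 1 gives 8900 nM. Compound 2 `CCOC(=O)C1=Cc2ccccc2OC1(OCc1cc(-c2ccc(F)cc2F)no1)C(F)(F)F` differs in the ring that links the shared core to the outer aryl ring and in the fluorine pattern on that aryl ring. In this assay compound 2 reaches only the limit of > 150000 nM, a boundary of the measurement rather than a number. Compound 3 `O=C(O)C1=Cc2ccccc2OC1(OCc1cc(-c2ccc(F)cc2F)no1)C(F)(F)F` carries a free acid where compound 2 carries an ethyl ester; in this assay compound 3 also stops at the limit of > 150000 nM. The step from compound 2 to compound 3 is therefore a step that the two limits leave unreadable from compound 2 to compound 3. The set is dominated by the limit of > 150000 nM in this assay, at which 2 of the 3 values shown sit, so compound 1 stands alone as the single readable point.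

Compound 4 `CCOC(=O)C1=Cc2ccccc2OC1(OCc1cn(-c2ccc([N+](=O)[O-])cc2)nn1)C(F)(F)F` is compound 1 with nitro in place of fluoro on an aromatic carbon. Going by the values given here, no measured step touches this position: the one measured step concerns the ester, and its size cannot be read. There is thus no basis to expect a shift beyond the usual scatter of this assay, in either direction. The expected step is no change at the digits printed from compound 1 to compound 4 (within the scatter). For compound 4 the estimated value in this assay is 8900 nM, with a range from 3000 nM to 27000 nM.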

Compound 4, half-maximal inhibitory concentration: > 150000 nM
Compound 4 gave a limit, no number; the forecaster's own chance of this, stated with the estimate: 5%; middle value at least 16-fold (1.22 log units) away from the limit.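

For the compounds shown here, this aromatic carbon, para to a large group, is the first place in the set where a single change has a readable effect: nitro in place of fluoro gives an at least 16-fold higher number from compound 1 to compound 4 (1.22 log units; beyond the scatter) in this assay. Compound 4 gives a limit and not a number, so this size is only the smallest the step can be, and the real step may be larger. The earlier compounds offered no measured step at this position, and the one step they did offer, at the ester, cannot be read; compound 1 now remains the only compound with a number, and activity in this set has so far been seen only with 4-fluorophenyl on the triazole-free reading of the data left aside, as the values show: the limit of > 150000 nM in this assay, at which 3 of the 4 values shown sit.

Still open, on these data alone, is whether fluoro itself matters or nitro alone is what is not tolerated, a question that hydrogen, chlorine, a methoxy group or an amine on this same aromatic carbon would help to settle. Also open, as far as these compounds go, is how the rest of compound 1 responds to change, for example an amide in place of its ethyl ester.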